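Methyl for trifluoromethyl on the ester ring: a second look

The compounds below may be only part of what the source reports. "The series", "measured", "known", "first", "only" and "open" are said of these compounds alone.

Three esters share one core and differ only in the group on the benzoate ring. Compound 1 `CC1=CC[C@H](C(C)C)c2cc(C)c(OC(=O)c3ccc(C)cc3)cc21` carries a methyl, compound 2 `CC1=CC[C@H](C(C)C)c2cc(C)c(OC(=O)c3ccc(C(F)(F)F)cc3)cc21` a trifluoromethyl, and compound 3 `CC1=CC[C@H](C(C)C)c2cc(C)c(OC(=O)c3cccc(C(F)(F)F)c3)cc21` a trifluoromethyl on the same ring. In a functional assay on U-251 cells (Homo sapiens) for antiproliferative activity, read by sulforhodamine B assay, with a stated time of 48 h, tested at 50 uM (on this read-out higher numbers stand for more inhibition at the one concentration tested (going by the name of the read-out) and lower numbers for less inhibition), compound 1 gives 67.7%, compound 2 gives 14.7%, and compound 3 gives 29.3%. The difference between compound 2 and compound 3 is not broken down here.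

One change has been measured: from compound 2 to compound 1 the step is a number 53 percentage points higher from compound 2 to compound 1 (beyond the scatter), and the change is methyl in place of trifluoromethyl on an aromatic carbon.

Compound 4 `CC1=CC[C@H](C(C)C)c2cc(C)c(OC(=O)c3cccc(C)c3)cc21` has not yet been measured in this assay. It differs from compound 3 by methyl in place of trifluoromethyl on an aromatic carbon. This is the same kind of change as from compound 2 to compound 1, though the group sits meta to a large group here and para to a large group there.

Because compound 2 to compound 1 rose by a number 53 percentage points higher from compound 2 to compound 1 (beyond the scatter), a step of about a number 32.7 percentage points higher from compound 3 to compound 4 (beyond the scatter) is expected from compound 3 to compound 4, somewhat smaller given the different place. Compound 4 is estimated at 62%, between 38% and 82%.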

Compound 4, a percentage reported as inhibition, at one concentration (the size of the read-out at that concentration, not a potency): 16.8%
Compound 4: the middle estimate sits 45.2 percentage points above what was measured; the measured number lies below the stated range.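

In this assay, methyl in place of trifluoromethyl does not carry over as one fixed step, because the result changes with where the group sits on the ester ring: the same change on two cores in this assay, a number 53 percentage points higher (beyond the scatter) from compound 2 to compound 1 and a number 12.5 percentage points lower (beyond the scatter) from compound 3 to compound 4, 65.5 percentage points apart, beyond the scatter of two such steps

At the new place, the swap gives a number 12.5 percentage points lower from compound 3 to compound 4 (beyond the scatter), and the methyl compounds themselves are far apart, with 3-methylphenyl in place of 4-methylphenyl on a carbonyl carbon giving a number 50.9 percentage points lower from compound 1 to compound 4 (beyond the scatter). This shows that, among these four compounds, a step measured at one place is a poor guide to the same swap at another, but it does not explain why, and each place rests on a single pair tested at one concentration.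

The compounds shown leave open whether the high number of compound 1 is special to methyl or would also appear with other groups at that place. An amine, a carboxylic acid or a longer chain on the ester ring could behave differently, and nothing here predicts how.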